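Swapping the Aryl Group on the Sulfonyl Sulfur

The source may hold more compounds than are shown below. What is called first, only, known or untested is meant among the compounds shown, and "the series" means these compounds.

Measured so far:
Compound 1 `COc1ccc(-c2cc(=O)c3c(OC)cc(OC)cc3n2S(=O)(=O)c2ccc([N+](=O)[O-])cc2)cc1` gives 17300 nM in a functional assay on KOPN-8 cells (Homo sapiens) for antiproliferative activity, with a stated time of 72 h; a lower number here means that less compound is needed, a higher number that more compound is needed for the effect.
Compound 2 `COc1ccc(-c2cc(=O)c3c(OC)cc(OC)cc3n2S(=O)(=O)c2cccc([N+](=O)[O-])c2)cc1` is reported in this assay only as a limit, > 39600 nM.

For the measured compounds named here, compound 1 is therefore the only compound with a definite number in this assay; the other value shown is a limit, not a measurement. Going by the values given here, the one measured step is an at least 2.2-fold higher number from compound 1 to compound 2 (0.35 log units; beyond the scatter), and how far it goes is bounded only by the limit of > 39600 nM in this assay, at which 1 of the 2 values shown sits, the edge of what the test can report.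

Compound 3 `COc1ccc(-c2cc(=O)c3c(OC)cc(OC)cc3n2S(=O)(=O)c2ccc(Br)s2)cc1` has not yet been measured. It differs from compound 1 by 5-bromothiophen-2-yl in place of 4-nitrophenyl on a sulfonyl sulfur. Among the compounds with values here, no measured step exchanges this group for a different ring, so the only guide is an at least 2.2-fold higher number from compound 1 to compound 2 (0.35 log units; beyond the scatter), which also altered the group on the sulfonyl sulfur and raised the number. Since the change to compound 3 is larger than that step, a similar or somewhat larger rise seems the more likely outcome. On that basis compound 3 is expected to show a 1.6-fold higher number from compound 1 to compound 3 (0.21 log units; within the scatter). The estimate for compound 3 in this assay is 28000 nM, expected to fall between 9000 nM and 80000 nM, with a fair chance that only a limit is returned.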

Compound 3, half-maximal effective concentration: > 48200 nM
Compound 3: no number, only a limit (the forecaster's own chance of this, stated with the estimate: 35%); middle value at least 1.7-fold (0.23 log units) from the limit.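

Exchanging 4-nitrophenyl for 5-bromothiophen-2-yl on the sulfonyl sulfur gives an at least 2.7-fold higher number from compound 1 to compound 3 (0.44 log units; beyond the scatter) in this assay, so replacing the six-membered ring with a five-membered one also raises the number, as moving the nitro group did. Compound 3 is reported only as a limit, > 48200 nM. Among the three groups shown on this sulfur, only the 4-nitrophenyl of compound 1 gives a definite number, and that number is the lowest, while the one new group tried here again ends at the edge of what the test can report: the limit of > 48200 nM in this assay, at which 1 of the 3 values shown sits.

Compound 2 and compound 3 both carry limits, so the step between them cannot be read and their two groups cannot be ranked against each other. Compound 1 gives 17300 nM. From the compounds shown here alone, it also remains open whether any other group on the sulfonyl sulfur, such as a phenyl ring carrying an amine or a carboxylic acid, or a simple alkyl chain in place of the ring, would bring the number lower.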